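Adding a Methyl to the Chlorophenyl Ring of Compound 1

A few compounds are considered here, and "the series" means these few. Any claim that something is new, unique, unknown or untested is made for them only; others in the source may bear on it.

Measured so far:
compound 1 `Cc1nc(-c2ccccc2F)c(C(=O)N2CCN(c3cccc(Cl)c3)CC2)o1`: 39.4 nM
compound 2 `Cc1nc(-c2ccc(F)cc2)c(C(=O)N2CCN(c3cccc(Cl)c3)CC2)o1`: 40.1 nM

Of the compounds shown here, two have been measured in a functional assay on HL-60 cells (Homo sapiens) for inhibition, read by MTT assay, with a stated time of 72 h; a higher number here means a weaker inhibitor, a lower number a stronger inhibitor. Compound 1 shows the lower of the two numbers, but the step of a 1.0-fold higher number from compound 1 to compound 2 (0.01 log units; within the scatter) lies within the scatter, so the two cannot be told apart. That step swapped 4-fluorophenyl for 2-fluorophenyl on an aromatic carbon and concerns only the fluorine-bearing ring.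

Compound 3 `Cc1nc(-c2ccccc2F)c(C(=O)N2CCN(c3cc(Cl)ccc3C)CC2)o1` has not yet been measured. It differs from compound 1 by methyl in place of hydrogen on an aromatic carbon. Going by the values given here, no measured step touches the chlorophenyl ring, so the data give no guide to what a methyl there will do. In that situation the plain expectation is a step no larger than the scatter, in no set direction: for compound 3 the estimated step is a 1.1-fold higher number from compound 1 to compound 3 (0.03 log units; within the scatter). Among the compounds with values here, compound 3 is therefore expected to give about 42 nM in this assay, with a likely range from 15 nM to 130 nM; the range is kept wide, as the change has no measured precedent here.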

Compound 3, half-maximal inhibitory concentration: 229 nM
Estimate against measurement, compound 3: 5.5-fold (0.74 log units) below; the whole stated range lies below it.
By their numbers in this assay, from the lowest: compounds 1 and 2 (each within the scatter of the next); then compound 3.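

The chlorophenyl ring is not indifferent to small changes: in this assay, going from 3-chlorophenyl to 5-chloro-2-methylphenyl gives a 5.8-fold higher number from compound 1 to compound 3 (0.76 log units; beyond the scatter), so compound 3 is a weaker inhibitor than compound 1. The change is small, a single added methyl of one heavy atom, placed ortho to a large group and para to the chloro group, yet the step lies beyond the scatter, which the earlier move of the fluorine on the other ring did not. The data available here offer no measurement that bears on the reason for this loss.

Going by these compounds, it remains open whether the loss is specific to methyl or would also follow from another group at this carbon, such as a fluorine atom, a methoxy group or an ethyl group. On these data alone, whether a methyl on a different carbon of this ring would have the same effect is also open.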